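A few compounds are considered here, and "the series" means these few. Any claim that something is new, unique, unknown or untested is made for them only; others in the source may bear on it.

Measured so far:
compound 1 `ClCc1cccc(Cn2cnc3ncnc(Cl)c32)c1`: 39000 nM
compound 2 `ClCc1cccc(Cn2cnc3c(Cl)ncnc32)c1`: the assay's limit > 100000 nM
compound 3 `ClCc1cccc(Cn2cnc3c(Cl)nc(Cl)nc32)c1`: the assay's limit > 100000 nM

In a functional assay on MCF7 cells (Homo sapiens) for cytotoxicity, read by sulforhodamine B assay, with a stated time of 48 h (on this read-out higher numbers stand for lower toxicity in this test and lower numbers for higher toxicity in this test), compound 1 is the only one of the three to give a number, 39000 nM. For compound 2 the value is a limit of the assay, not a number. For compound 3 the value is likewise only a limit. This means (the limit of > 100000 nM in this assay, at which 2 of the 3 values shown sit), so the step that the two limits leave unreadable from compound 2 to compound 3 cannot be read.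

Compound 1 and compound 2 are built from the same atoms joined differently; how their two cores differ is not broken down here. Compound 4 `ClCc1cccc(Cn2cnc3nc(Cl)nc(Cl)c32)c1` is not yet measured. It differs from compound 1 by chloro in place of hydrogen on an aromatic carbon, and this is the same change as chloro in place of hydrogen on an aromatic carbon, made at the same kind of place. Since the measured step gives no readable size, the expectation for compound 4 rests on compound 1 at 39000 nM with little movement assumed. A result for compound 4 that is only a limit of the assay is also quite possible. Compound 4 is expected to give about 60000 nM, between 20000 nM and 150000 nM. The expected step is a 1.5-fold higher number from compound 1 to compound 4 (0.19 log units; within the scatter).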

Compound 4, concentration lethal to 50% of the cells: > 100000 nM
Compound 4: a limit, no number; the forecaster's own chance of this, stated with the estimate: 45%; middle value at least 1.6-fold (0.22 log units) away from the limit.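

In this assay, chloro in place of hydrogen on the aromatic carbon between two ring nitrogen atoms gives an at least 2.5-fold higher number from compound 1 to compound 4 (0.40 log units; beyond the scatter). The value of compound 4 is a limit, not a number, and the matching step from compound 2 to compound 3 cannot be read, so nothing shows whether the change has the same size on both cores. The comparison can go no further because most of the values sit at one ceiling: the limit of > 100000 nM in this assay, at which 3 of the 4 values shown sit.

The compounds shown leave open what a different group at that same carbon, such as an amine or a methoxy group, would do to the read-out. They also leave open whether a methyl or hydroxymethyl group in place of the chloromethyl group would shift the value of compound 1, which stands at 39000 nM in this assay.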